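Compound 1 to Compound 4: a Smaller Aromatic Ring

The source may report more compounds than this note shows. Statements on the series, on what has been measured and on what is new or still open speak of the compounds shown alone.

Of the compounds shown here, three sharing one core have been tested in a functional assay on UACC-62 cells (Homo sapiens) for inhibition, read by sulforhodamine B assay, with a stated time of 48 h; on this read-out higher numbers stand for weaker inhibition of growth and lower numbers for stronger inhibition of growth. Compound 1 `COc1ccc(/C=N/NC(=S)NC(C)(C)[C@H]2CC=C(C)CC2)cc1` gives 70400 nM in this assay. Compound 2 `COc1cc(/C=N/NC(=S)NC(C)(C)[C@H]2CC=C(C)CC2)ccc1O` gives 42300 nM in this assay, a number within the usual scatter of that of compound 1; the two cannot be told apart. Compound 3 `CC1=CC[C@H](C(C)(C)NC(=S)N/N=C/c2cccc([N+](=O)[O-])c2)CC1` reaches only a limit of this assay, > 100000 nM, and no number is known for it. Among the two numbers shown, compound 1 holds the higher one, with compound 2 its nearest neighbour inside the scatter. The unmeasured compound 4 `CC1=CC[C@H](C(C)(C)NC(=S)N/N=C/c2cccs2)CC1` differs from compound 1 in one place: thiophen-2-yl in place of 4-methoxyphenyl on a carbon with a double bond to nitrogen. Going by the values given here, no measured pair differing in one place is at hand, and the size of this step is unknown. All values here are weak, one of three sitting at the limit of > 100000 nM in this assay, at which 1 of the 3 values shown sits. The expected step is a 1.1-fold higher number from compound 1 to compound 4 (0.06 log units; within the scatter), not beyond the scatter. Compound 4 is estimated at 80000 nM, with a range from 35000 nM to 160000 nM.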

Compound 4, concentration for total growth inhibition: 19000 nM
Beside the measured number, compound 4's estimate is 4.2-fold (0.62 log units) above it; measured number below the stated range.
By their numbers in this assay, from the lowest: compound 4; then compounds 2 and 1 (each within the scatter of the next). At a limit, above all of these: compound 3.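

In this assay, the group on the carbon with a double bond to nitrogen clearly makes a difference: thiophen-2-yl in place of 4-methoxyphenyl gives a 3.7-fold lower number from compound 1 to compound 4 (0.57 log units; beyond the scatter). Going by these compounds alone, this is the only step that can be read as one change, and the size of the step is modest. It shows that a six-membered aromatic ring of carbon only is not required at this place, since a five-membered aromatic ring with sulfur as its hetero atom gives a lower number, meaning stronger inhibition of growth.

The compounds shown do not separate the effect of the smaller ring from that of its sulfur atom, a question that furan-2-yl, with oxygen in the ring instead, could help settle. Compound 3 also stays at a limit of the assay and gives no number: the limit of > 100000 nM in this assay, at which 1 of the 4 values shown sits.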